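The source may hold more compounds than are shown below. What is called first, only, known or untested is meant among the compounds shown, and "the series" means these compounds.

In a functional assay on DU-145 cells (Homo sapiens) for cytotoxicity, read by trypan blue exclusion, with a stated time of 96 h (a lower number here means a stronger inhibitor, a higher number a weaker inhibitor), compound 1 (`COc1ccccc1/C=C/S(=O)(=O)Cc1ccc(OC)c([N+](=O)[O-])c1`) gives 20000 nM, and compound 2 (`COc1ccc(CS(=O)(=O)/C=C/c2c(OC)cc(OC)cc2OC)c(N)c1`) gives 25 nM. Compound 3 (`COC(=O)CCNc1cc(CS(=O)(=O)/C=C/c2c(OC)cc(OC)cc2OC)ccc1OC`) stands between them at 1500 nM, the second highest of the three numbers and beyond the usual scatter from each of the others.

Compound 4 (`COc1cc(OC)c(/C=C/S(=O)(=O)Cc2ccc(OC)c(NCCC(=O)O)c2)c(OC)c1`) differs from compound 3 in one place: hydrogen in place of methyl on an oxygen next to a carbonyl group. This puts hydrogen in place of methyl on an oxygen next to a carbonyl group, so methoxycarbonyl becomes carboxy. Within the data shown here, no two measured compounds differ in only one place, so the data offer no direct guide to the effect of this change in this assay. The only hint is that compound 2 reaches 25 nM, which shows that much lower numbers than that of compound 3 occur among these few compounds. A moderate step towards a lower number, meaning a stronger inhibitor, is therefore expected, with wide uncertainty. The expected change is a 3.8-fold lower number from compound 3 to compound 4 (0.57 log units; beyond the scatter). For compound 4 the estimated value is 400 nM, with an expected range from 40 nM to 4000 nM.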

Compound 4, half-maximal inhibitory concentration: 5000 nM
Compound 4: the middle estimate sits 13-fold (1.10 log units) below what was measured; the whole stated range lies below it.
By their numbers in this assay, from the lowest: compound 2; then compound 3; then compound 4; then compound 1.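

In this assay, among these compounds, the change from methoxycarbonyl to carboxy gives a 3.3-fold higher number from compound 3 to compound 4 (0.52 log units; beyond the scatter) and this is the first pair in the set that differs in only one place. The direct reading is therefore that, at this end of the side chain, the methyl ester is the stronger inhibitor of the two, though the step is modest and compound 4 still has a measurable value. Nothing measured here explains the direction of this step.

On these data alone, it remains open whether this shift is specific to the carboxylic acid or whether other groups at the same place would behave in the same way. An amide, an ethyl ester or a longer chain ending in a carboxylic acid could each help to settle that question.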